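A few compounds are considered here, and "the series" means these few. Any claim that something is new, unique, unknown or untested is made for them only; others in the source may bear on it.

Compound 1 `CCc1ccc(Nc2cc(NC(=O)Nc3c(Cl)cccc3Cl)ncn2)cc1` gives 39.5% in a functional assay on NCI-H226 cells (Homo sapiens) for inhibition, read by MTT assay, with a stated time of 48 h, tested at 10 uM; on this read-out higher numbers stand for more inhibition at the one concentration tested (going by the name of the read-out) and lower numbers for less inhibition; compound 2 `COc1ccc(F)cc1Nc1cc(NC(=O)Nc2c(Cl)cccc2Cl)ncn1` gives 31.3%.

Compound 2 stands lowest of the two numbers in this assay, and the step of a number 8.2 percentage points lower from compound 1 to compound 2 (within the scatter) lies within the scatter. Compound 3 `Cc1cc(F)cc(Nc2cc(NC(=O)Nc3c(Cl)cccc3Cl)ncn2)c1` differs from compound 2 by 3-fluoro-5-methylphenyl in place of 5-fluoro-2-methoxyphenyl on a nitrogen on an aromatic ring. Within the data shown here, only that one step bears on this change, and its size suggests that swapping the aryl group on this nitrogen does little here. Compound 3 is therefore expected to give a step of a number 3.7 percentage points higher from compound 2 to compound 3 (within the scatter), none beyond the scatter, and its estimate is 35% within the range 22% to 50%.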

Compound 3, a percentage reported as inhibition, at one concentration (the size of the read-out at that concentration, not a potency): 78.1%
Beside the measured number, compound 3's estimate is 43.1 percentage points below it, outside the stated range (above it).
By their numbers in this assay, from the lowest: compounds 2 and 1 (each within the scatter of the next); then compound 3.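

In this assay the aryl group on this nitrogen proves able to shift the result far beyond the scatter: 3-fluoro-5-methylphenyl brings a number 46.8 percentage points higher from compound 2 to compound 3 (beyond the scatter) and, in place of 4-ethylphenyl, a number 38.6 percentage points higher from compound 1 to compound 3 (beyond the scatter) on the same core. The earlier swap at this place had stayed within the scatter, so that step did not show how much this position can respond. No measurement at hand explains the gain.

The compounds shown leave open whether the fluoro or the methyl of the new group carries it, and how a phenyl with a chloro or an amino group would read here.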